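Aryl variation on a benzhydryl-ester penam core

A few compounds are considered here, and "the series" means these few. Any claim that something is new, unique, unknown or untested is made for them only; others in the source may bear on it.

Measured compounds:
compound 1 `CC1(C)S[C@@H]2/C(=C\C(=O)c3cc(F)cc(F)c3)C(=O)N2[C@H]1C(=O)OC(c1ccccc1)c1ccccc1` gives 17600 nM in a functional assay on OE19 cells (Homo sapiens) for cytotoxicity, read by MTT assay, with a stated time of 48 h; on this read-out lower numbers stand for stronger inhibition and higher numbers for weaker inhibition
compound 2 `CC1(C)S[C@@H]2C/C(=C\C(=O)c3ccccc3)C(=O)N2[C@H]1C(=O)OC(c1ccccc1)c1ccccc1` gives 73300 nM in this assay
compound 3 `CC1(C)[C@H](C(=O)OC(c2ccccc2)c2ccccc2)N2C(=O)/C(=C/C(=O)c3ccccc3)[C@H]2[S+]1[O-]` gives 23700 nM in this assay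

Compound 1 stands at the lowest of the three numbers in this assay. Its nearest neighbour is compound 3, whose number is higher by an amount within the usual scatter, so the two cannot be told apart on these data. Compound 2 sits furthest away, with a number higher by a margin that lies beyond the scatter.

Compound 4 `CC1(C)S[C@@H]2/C(=C\C(=O)c3ccc(C(F)(F)F)cc3)C(=O)N2[C@H]1C(=O)OC(c1ccccc1)c1ccccc1` has not yet been measured in this assay. It differs from compound 1 in one place: 4-(trifluoromethyl)phenyl in place of 3,5-difluorophenyl on a carbonyl carbon. For the measured compounds named here, all three measured compounds keep the aroyl group on the double-bonded chain carbon, and no measured pair shows what changing the substituents on that aryl ring does, so there is no measured step to lean on.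

With the aroyl arrangement of compound 1 retained and only the ring substitution pattern changed, the step from compound 1 to compound 4 is expected to be small, a 1.1-fold higher number from compound 1 to compound 4 (0.06 log units; within the scatter), within the scatter in either direction. The number expected for compound 4 is 20000 nM, with a range from 8000 nM to 50000 nM.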

Compound 4, half-maximal inhibitory concentration: 15600 nM
For compound 4 the middle estimate is 1.3-fold (0.11 log units) above the measured one; low and high end bracket the measured number.
By their numbers in this assay, from the lowest: compounds 4, 1 and 3 (each within the scatter of the next); then compound 2.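

In this assay, for the compounds shown here, the change from 3,5-difluorophenyl to 4-(trifluoromethyl)phenyl on a carbonyl carbon gives a 1.1-fold lower number from compound 1 to compound 4 (0.05 log units; within the scatter), the first measured step at this position. The two compounds cannot be told apart, so within this one pair the aryl ring tolerates a different fluorine count, a different substitution pattern and a group with more heavy atoms, with no measurable change in the read-out. Nothing available explains why the two compounds match, as no independent measurement bears on this result.

Compound 2 and compound 3 carry an unsubstituted phenyl ring but also differ from compound 1 elsewhere, so what either fluorinated substituent contributes relative to plain phenyl cannot be read from these compounds. Both compounds in the step also carry only fluorine-bearing substituents on the ring, which leaves open whether this flat result would hold for an aryl ring bearing an amine, a carboxylic acid or a methoxy group, or for a longer chain in place of the aryl ring on the same carbonyl carbon.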